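Removing One Chloro Group from Compound 3

The source may hold more compounds than are shown below. What is called first, only, known or untested is meant among the compounds shown, and "the series" means these compounds.

Three measured compounds share one core and differ only in the aromatic group attached to it: compound 1 `Clc1ccc(-c2nc(N3CCCCC3)c3nc[nH]c3n2)cc1`, compound 2 `Oc1cccc(-c2nc(N3CCCCC3)c3nc[nH]c3n2)c1` and compound 3 `Clc1ccc(Cl)c(-c2nc(N3CCCCC3)c3nc[nH]c3n2)c1`. In an assay on cells for displacement of a labelled ligand from adenosine receptor A3 (Homo sapiens), read by scintillation counting and radioligand binding, with a stated time of 180 min, tested at 10 uM (a lower number here means less inhibition, a higher number more inhibition at the concentration tested (going by the name of the read-out)), compound 1 gives > 80%, which is a limit of the assay rather than a number. Compound 2 gives > 80%, again a limit. Compound 3 stands at > 80%, also a limit. For the measured compounds named here, the only step between measured compounds, a step that the two limits leave unreadable from compound 1 to compound 2, cannot be read because both ends sit at the limit (the limit of > 80% in this assay, at which 3 of the 3 values shown sit).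

Compound 4 `Clc1cccc(-c2nc(N3CCCCC3)c3nc[nH]c3n2)c1` is not yet measured and differs from compound 3 by hydrogen in place of chloro on an aromatic carbon. Going by the values given here, no measured step shows how this change moves the read-out. Compound 4 is therefore expected to land at about 85%, between 70% and 98%, an expected step that the limit leaves unreadable from compound 3 to compound 4 of no size beyond the scatter.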

Compound 4, a percentage reported as inhibition, at one concentration (the size of the read-out at that concentration, not a potency): > 80%
Compound 4 was reported as a limit; the forecaster's own chance of this, stated with the estimate: 75%; the middle value lies beyond the limit too.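

The steps to compound 4 from compound 1, compound 2 and compound 3 cannot be read, because every end of them is a limit: the limit of > 80% in this assay, at which 4 of the 4 values shown sit.

Going by these compounds, whether changing the aromatic group on the shared core moves the read-out in this assay at all remains open.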